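Ester to acid on a CDK8/Cyclin C cinnamate series

The source may report more compounds than this note shows. Statements on the series, on what has been measured and on what is new or still open speak of the compounds shown alone.

Measured compounds:
compound 1 `CCOC(=O)/C=C/c1ccncc1-c1ccc2[nH]ccc2c1` 100%
compound 2 `COC1CN(C(=O)/C=C/c2ccncc2-c2ccc(F)cc2)C1` 77%
compound 3 `CCOC(=O)/C=C/c1ccncc1-c1ccc2c(ccn2C)c1` 100%

In an assay on a protein complex for inhibition of CDK8/Cyclin C (Homo sapiens), with a stated time of 1 h, tested at 10 uM (a lower number here means less inhibition, a higher number more inhibition at the concentration tested (going by the name of the read-out)), compound 3 stands level with compound 1, the two together the highest of the three numbers, while compound 2 lies lower by an amount beyond the scatter. Within the data shown here, the only single-place step measured, no change at the digits printed from compound 1 to compound 3 (within the scatter), touches the aromatic nitrogen and not the ester, so no measured step bears directly on the change to compound 4 `Cn1ccc2cc(-c3cnccc3/C=C/C(=O)O)ccc21`, in which (hydrogen in place of ethyl on an oxygen next to a carbonyl group). Among the measured compounds shown here, with no precedent for the ethyl-to-hydrogen change, and compound 3 already at the top of the range, a step downward of uncertain size, a number 25 percentage points lower from compound 3 to compound 4 (beyond the scatter), is expected. Compound 4 is therefore estimated at 75%, within 40% to 100%.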

Compound 4, a percentage reported as inhibition, at one concentration (the size of the read-out at that concentration, not a potency): 102%
Beside the measured number, compound 4's estimate is 27 percentage points below it, and the stated range ends below it.
By their numbers in this assay, from the lowest: compound 2; then compounds 1, 3 and 4 (each within the scatter of the next).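

In this assay, the change from ethoxycarbonyl to carboxy gives a number 2 percentage points higher from compound 3 to compound 4 (within the scatter), so at this position the ethyl on the oxygen next to a carbonyl group can give way to hydrogen with no loss of inhibition at the concentration tested. The free carboxy group keeps the read-out at the level of the ethyl esters. Nothing shown gives a reason for this result.

On these data alone, a single concentration gives no potency, so any difference in potency between compound 3 and compound 4 stays open. As far as these compounds go, how a tetrazole or a butyl ester would read at this position also stays open.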